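A few compounds are considered here, and "the series" means these few. Any claim that something is new, unique, unknown or untested is made for them only; others in the source may bear on it.

Compound 1 (`Cc1nn(-c2ccccc2)c2nc(-c3ccccc3)c(C#N)c(-c3ccccc3O)c12`) is the starting point, and it was tested in an ADME assay on BJ cells (Homo sapiens) for cytotoxicity, with a stated time of 72 h; a lower number here means that less compound is needed, a higher number that more compound is needed for the effect. There compound 1 gives > 23000 nM as a limit of the assay, not a number. The change to compound 4 (`CCCc1ccc(-c2nc3c(c(C)nn3-c3ccccc3)c(-c3ccccc3O)c2C#N)cc1`) is propyl in place of hydrogen on an aromatic carbon and reads as propyl in place of hydrogen on an aromatic carbon, or phenyl to 4-propylphenyl when cut one bond further out.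

Going by the values given here, no measured step covers this change directly. The nearest evidence comes from two compounds that carry an ethyl chain and lack the hydroxyl group of compound 1. Compound 2 (`CCc1ccc(-c2nc3c(c(C)nn3-c3ccccc3)c(-c3ccccc3Br)c2C#N)cc1`) gives > 20000 nM as a limit. Compound 3 (`CCc1ccc(-c2nc3c(c(C)nn3-c3ccccc3)c(-c3ccccc3)c2C#N)cc1`) gives > 20000 nM as a limit too. Among the compounds with values here, the one measured step is a step that the two limits leave unreadable from compound 2 to compound 3 and it concerns the exchange of bromo for hydrogen, not the addition of a chain. It therefore gives no size to carry over.

With compound 3 at > 20000 nM as a limit, no step beyond the scatter is expected in this assay and no direction can be given. The estimated change is an at least 1.1-fold lower number from compound 1 to compound 4 (0.06 log units; that floor lies within the scatter) on this expectation. For compound 4 the expected value is 20000 nM with an estimated range from 8000 nM to 40000 nM in this assay, and a report of only a limit is the likeliest outcome.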

Compound 4, half-maximal effective concentration: 22500 nM
Compound 4: the middle estimate sits 1.1-fold (0.05 log units) below what was measured; the range from low to high includes it.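

In this assay compound 4 gives a true number, 22500 nM, so this series can reach a readable value in this assay when the hydroxyl group is kept and a propyl chain stands on the aromatic carbon para to a large group. The other compounds shown gave only limits. The change of phenyl to 4-propylphenyl gives an at least 1.0-fold lower number from compound 1 to compound 4 (0.00 log units; that floor lies within the scatter), which fixes a direction with a floor and shows no shift beyond the usual scatter of this assay. The step has only a floor and no measured size because compound 1 is held at a limit: the limit of > 23000 nM in this assay, at which 1 of the 4 values shown sits.

The compounds shown leave open how far the number lies from compound 1 to compound 4, and whether the propyl chain matters at all or the value of compound 4 merely sits close to where compound 1 would read. They also leave open what a longer chain such as butyl, an amine or a carboxylic acid would do at the same place on the 4-propylphenyl ring, and how the ethyl and propyl chains compare with the hydroxyl group held constant.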